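Chlorine Position on the Benzyl Thioether and Arterial Inhibition

The source may report more compounds than this note shows. Statements on the series, on what has been measured and on what is new or still open speak of the compounds shown alone.

Compound 1 `COc1ccc(C2N=C(SCc3ccccc3Cl)NC(C)=C2C(=O)Nc2ccc(F)cc2)cc1OC` gives 30.3% in a functional assay on the whole organism (artery, strain albino) with Rattus norvegicus as the target, with a stated time of 240 min, at a dose of 10 mg/kg by the oral route; a lower number here means less inhibition, a higher number more inhibition at the dose given (going by the name of the read-out). Compound 2 `COc1ccc(C2N=C(SCc3cccc(Cl)c3)NC(C)=C2C(=O)Nc2ccc(F)cc2)cc1OC` carries the change 3-chlorophenyl in place of 2-chlorophenyl on a saturated chain carbon bound to a sulfur and gives 14.9% in this assay, so that a number 15.4 percentage points lower from compound 1 to compound 2 (beyond the scatter). Compound 3 `CC1=C(C(=O)Nc2ccc([N+](=O)[O-])cc2)C(c2cccc([N+](=O)[O-])c2)N=C(SCc2ccccc2Cl)N1` rests on a different core, and the difference between the two cores is not broken down here; in this assay compound 3 gives 12.8%, a reading that lies within the scatter of compound 2 and that compound 1 exceeds by a margin beyond the scatter. Compound 4 `CC1=C(C(=O)Nc2ccc([N+](=O)[O-])cc2)C(c2cccc([N+](=O)[O-])c2)N=C(SCc2cccc(Cl)c2)N1`, not yet measured, is related to compound 3 by 3-chlorophenyl in place of 2-chlorophenyl on a saturated chain carbon bound to a sulfur, the same change that separates compound 1 from compound 2, made at the same place. For the measured compounds named here, the single measured instance of this change lowered inhibition, and compound 3 begins from a low reading, so a smaller step is expected: a number 7.8 percentage points lower from compound 3 to compound 4 (within the scatter) is the estimated step, because the earlier step of a number 15.4 percentage points lower from compound 1 to compound 2 (beyond the scatter) cannot be repeated in full without passing zero inhibition. Compound 4 is therefore expected to give 5% in this assay, with the estimate ranging from 0% to 15%.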

Compound 4, a percentage reported as inhibition, in the whole organism at one dose (the size of the read-out at that dose, not a potency): 17.9%
For compound 4 the middle estimate is 12.9 percentage points below the measured one, outside the stated range (above it).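

In this assay, replacing 2-chlorobenzyl with 3-chlorobenzyl on the core of compound 3 gives a number 5.1 percentage points higher from compound 3 to compound 4 (within the scatter), so the drop seen for a number 15.4 percentage points lower from compound 1 to compound 2 (beyond the scatter) does not reappear on this second core. The change therefore does not carry over from one core to the other with a fixed size, and the result on one core does not predict the result on the other: the same change on two cores in this assay, a number 15.4 percentage points lower (beyond the scatter) from compound 1 to compound 2 and a number 5.1 percentage points higher (within the scatter) from compound 3 to compound 4, 20.5 percentage points apart, beyond the scatter of two such steps This rests on a single pair on each core at one oral dose, so it does not show which part of the difference between the cores goes with the gap, nor how the change would behave on any further core.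

The compounds shown leave open how a plain benzyl or a phenethyl chain would read in place of the chlorobenzyl groups on either core. They also leave open whether the contrast between the two pairs would hold at other doses.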